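This account rests on a few compounds, and the source may have more. Where it says the series, first, only, none or still open, it means among the compounds named here.

Cytotoxicity across the series is followed in an ADME assay on cells (Mus musculus) for cytotoxicity, read by MTT assay; a higher number here means that more compound is tolerated, a lower number that less compound is tolerated. Compound 1 `CCc1nnn(Cc2ccccc2)c1CCO` and compound 3 `CCc1nnn(Cc2cccc(C#N)c2)c1CCO` share one core; compound 2 `CCc1c(CCO)nnn1Cc1ccccc1` has the same atoms joined differently, and the difference between the two cores is not broken down here. In this assay compound 1 gives only a limit, > 100000 nM. Compound 2 likewise gives only a limit, > 100000 nM. Compound 3 also reaches only a limit, > 100000 nM. The change from compound 1 to compound 3 is cyano in place of hydrogen on an aromatic carbon, and its step in this assay is a step that the two limits leave unreadable from compound 1 to compound 3 because of the limit of > 100000 nM in this assay, at which 3 of the 3 values shown sit. Compound 4 `CCc1c(CCO)nnn1Cc1cccc(C#N)c1` is not yet measured and carries the same change from compound 2, (cyano in place of hydrogen on an aromatic carbon). The step is estimated at a step that the limit leaves unreadable from compound 2 to compound 4, resting on a step that the two limits leave unreadable from compound 1 to compound 3. Compound 4 is expected to give about 150000 nM, most likely again only a limit.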

Compound 4, half-maximal cytotoxic concentration: > 100000 nM
Compound 4 ended at the assay's limit; the forecaster's own chance of this, stated with the estimate: 85%; the middle value does not contradict the limit.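

No step can be read from compound 2 to compound 4, because both results are limits: the limit of > 100000 nM in this assay, at which 4 of the 4 values shown sit.

The compounds shown leave open whether cyano in place of hydrogen on an aromatic carbon, or the difference between the two cores, has any effect in this assay.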